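This account rests on a few compounds, and the source may have more. Where it says the series, first, only, none or still open, it means among the compounds named here.

In a functional assay on MDA-MB-436 cells (Homo sapiens) for antiproliferative activity, read by MTT assay, with a stated time of 24 h (a lower number here means a stronger inhibitor, a higher number a weaker inhibitor), compound 1 `CC(C)(C)c1ccc(C(CC(=O)O)NS(=O)(=O)c2ccc(C(F)(F)F)cc2)cc1` gives 60100 nM while compound 2 `O=C(O)CC(NS(=O)(=O)c1cc(F)cc(F)c1)c1ccccc1F` gives 89300 nM and compound 3 `O=C(O)CC(NC(=O)c1ccc(F)cc1)c1ccc(Cl)cc1Cl` gives 55800 nM as its result. These numbers lie within the usual scatter of each other, so compound 3 stands level with the other two and no ranking can be drawn. Compound 4 `COc1ccccc1C(=O)NC(CC(=O)O)c1ccc(Cl)cc1Cl` comes from compound 3 by one change, with 2-methoxyphenyl in place of 4-fluorophenyl on a carbonyl carbon. Among the compounds with values here, no measured pair differs in one place only, so the size of this swap cannot be read directly. Compound 2 (89300 nM) and compound 3 (55800 nM) differ in more than one place and still sit within the scatter, so no step beyond the scatter is expected in this assay in either direction. The estimate amounts to an expected step of a 1.1-fold higher number from compound 3 to compound 4 (0.03 log units; within the scatter) that stays inside the scatter. Compound 4 is expected at 60000 nM with a likely range from 30000 nM to 110000 nM when measured.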

Compound 4, half-maximal inhibitory concentration: > 100000 nM
Compound 4: no number, only a limit; the forecaster's own chance of this, stated with the estimate: 10%; middle value at least 1.6-fold (0.22 log units) from the limit.
By their numbers in this assay, from the lowest: compounds 3, 1 and 2 (each within the scatter of the next). At a limit, above all of these: compound 4.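

In this assay compound 4 gives > 100000 nM, which is a limit of the assay and not a number. Placing 2-methoxyphenyl in place of 4-fluorophenyl on a carbonyl carbon is the first change here that can be read on its own, and the result is an at least 1.7-fold higher number from compound 3 to compound 4 (0.25 log units; that floor lies within the scatter), so this swap gives no sign of a stronger inhibitor, though its floor alone does not establish a real loss. The true size of the step stays unknown, and the result rests on a limit: the limit of > 100000 nM in this assay, at which 1 of the 4 values shown sits.

From the compounds shown here alone, whether a plain phenyl, or a phenyl carrying an amine, would give a measurable number on that carbonyl carbon remains open. Also open, going by these compounds, is whether the same swap would read the same way on a core other than that of compound 3.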